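The compounds below may be only part of what the source reports. "The series", "measured", "known", "first", "only" and "open" are said of these compounds alone.

Measured so far:
compound 1, `O=C(O)Cc1sc(COc2ccc(Cl)cc2)nc1-c1ccc(Cl)cc1`, 32 nM
compound 2, `O=C(O)Cc1sc(C(c2ccc(F)cc2)c2ccc(F)cc2)nc1-c1ccco1`, 18 nM

In an in vitro assay on HEK385-7 cells for displacement of a labelled ligand from prostaglandin D2 receptor 2 (Homo sapiens) (on this read-out lower numbers stand for stronger inhibition and higher numbers for weaker inhibition), compound 2 gives the lower of the two numbers, yet its gap to compound 1 lies within the scatter, so the two cannot be told apart. Compound 3, `Cc1cc(-c2nc(C(c3ccc(F)cc3)c3ccc(F)cc3)sc2CC(=O)O)ccn1`, is not yet measured. It differs from compound 2 by 2-methylpyridin-4-yl in place of furan-2-yl on an aromatic carbon; the carboxymethyl group and the large group on the shared core are kept. For the measured compounds named here, no measured pair isolates such a change, so nothing here tells its direction. The step from compound 2 to compound 3 in this assay, a 1.4-fold higher number from compound 2 to compound 3 (0.14 log units; within the scatter), is expected to stay within the scatter. For compound 3 the estimate is 25 nM, in the range 8 nM to 80 nM.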

Compound 3, half-maximal inhibitory concentration: 3.1 nM
Compound 3: middle estimate off by 8.1-fold (0.91 log units), on the high side; the measured number lies below the stated range.
By their numbers in this assay, from the lowest: compound 3; then compounds 2 and 1 (each within the scatter of the next).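

At the aromatic carbon next to the ring nitrogen, the choice of aromatic group affects the result: in this assay, 2-methylpyridin-4-yl in place of furan-2-yl gives a 5.8-fold lower number from compound 2 to compound 3 (0.76 log units; beyond the scatter) with the carboxymethyl group and the large group kept. For the compounds shown here, this single pair is the first readable step at this position, and the six-membered ring with its added methyl group is accommodated here. No data shown here bear on the origin of this step. Still open, going by these compounds, is whether the methyl group or the ring nitrogen accounts for it; a phenyl or pyridin-4-yl group at this carbon would separate the two.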